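The compounds below may be only part of what the source reports. "The series", "measured", "known", "first", "only" and "open" are said of these compounds alone.

Measured compounds:
- compound 1, `CCS(=O)(=O)Nc1ccc(NC(=O)c2ccc(C#N)cc2)cc1C`. In an ADME assay on HEK293 cells (Homo sapiens) for cytotoxicity, read by MTT assay, with a stated time of 48 h (on this read-out higher numbers stand for weaker inhibition and lower numbers for stronger inhibition), compound 1 gives > 250000 nM, a limit of the assay rather than a number.
- compound 2, `CCS(=O)(=O)Nc1ccc(NC(=O)c2ccc(C#N)cc2)cc1Cl`. In this assay compound 2 gives > 250000 nM, again a limit of the assay and not a number.

Compound 2 therefore stands at the limit only; where it lies beyond that is not known. Among the compounds with values here, the one measured step, a step that the two limits leave unreadable from compound 1 to compound 2, is left unreadable, since both ends of it sit on (the limit of > 250000 nM in this assay, at which 2 of the 2 values shown sit).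

Compound 3, `CCS(=O)(=O)Nc1ccc(NC(=O)c2ccc(C#N)cc2)cc1F`, differs from compound 2 by fluoro in place of chloro on an aromatic carbon. Within the data shown here, the only measured step that bears on this is the one from compound 1 to compound 2, a swap of one halogen-sized substituent on the same aromatic carbon, and that step gave no readable size. Nothing in the two values shown points to a step in either direction beyond the scatter, and the most likely outcome is that compound 3 is again reported as a limit. The step from compound 2 to compound 3 is expected to be a step that the limit leaves unreadable from compound 2 to compound 3. Compound 3 is estimated at 300000 nM, with a range from 150000 nM to 700000 nM, most probably returned as a limit.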

Compound 3, half-maximal inhibitory concentration: 26400 nM
Compound 3: middle estimate off by 11-fold (1.06 log units), on the high side; measured number outside the range, below it.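

In this assay, the aromatic carbon ortho to the (ethylsulfonyl)amino group proves able to move the read-out, which the earlier pair could not show: an at least 9.4-fold lower number from compound 2 to compound 3 (0.97 log units; beyond the scatter), and an at least 9.4-fold lower number from compound 1 to compound 3 (0.97 log units; beyond the scatter). Both steps lie beyond the scatter and point towards stronger inhibition, so among the three groups seen at this place, fluoro alone gives a number rather than a limit. The printed steps are therefore lower bounds on the change and not its full size, because compound 1 and compound 2 stand only at a limit: the limit of > 250000 nM in this assay, at which 2 of the 3 values shown sit.

The step between compound 1 and compound 2 still cannot be read, so no order can be given for methyl and chloro, and the series does not show whether the drop belongs to fluoro alone or would also appear with a hydroxy, methoxy or amino group on the same carbon. From the compounds shown here alone, it also remains open whether fluoro at this place gives a similar step when the ethyl on the sulfonyl is replaced by a longer chain or the nitrile by a carboxylic acid.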